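A few compounds are considered here, and "the series" means these few. Any claim that something is new, unique, unknown or untested is made for them only; others in the source may bear on it.

Compound 2 `CC(=O)Nc1cccc(Oc2nc(NCC3CCOCC3)n3ncc(-c4ccc(C(=O)NC5CC5)c(C)c4)c3n2)c1` gives 1300 nM in a functional assay on HCT-116 cells (Homo sapiens) for antiproliferative activity (a higher number here means a weaker inhibitor of growth, a lower number a stronger inhibitor of growth), the highest of the two numbers measured; its nearest neighbour is compound 1 `Cc1cc(-c2cnn3c(NCC4CCOCC4)nc(NC4CCOCC4)nc23)ccc1C(=O)NC1CC1`, which in this assay gives 280 nM, the step being a 4.6-fold higher number from compound 1 to compound 2 (0.67 log units; beyond the scatter). Compound 3 `Cc1cc(-c2cnn3c(NCC4CCOCC4)nc(Oc4cccc(F)c4F)nc23)ccc1C(=O)NC1CC1` differs from compound 2 by 2,3-difluorophenyl in place of 3-acetamidophenyl on an oxygen on an aromatic ring. Among the compounds with values here, no measured step exchanges one aryl group for another on that oxygen; the only step seen, a 4.6-fold higher number from compound 1 to compound 2 (0.67 log units; beyond the scatter), replaces the whole (oxan-4-yl)amino by 3-acetamidophenoxy and does not bear on it. The step of a 1.3-fold lower number from compound 2 to compound 3 (0.11 log units; within the scatter) is therefore expected to stay within the scatter. Compound 3 is estimated at 1000 nM, range 250 nM to 4000 nM.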

Compound 3, concentration for 50% growth inhibition: 9 nM
Compound 3: middle estimate off by 110-fold (2.05 log units), on the high side, and the stated range ends above it.
By their numbers in this assay, from the lowest: compound 3; then compound 1; then compound 2.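

In this assay, the aryl group on this oxygen carries a large effect: 2,3-difluorophenyl in place of 3-acetamidophenyl gives a 140-fold lower number from compound 2 to compound 3 (2.16 log units; beyond the scatter). An aryloxy group here is therefore not a loss in itself, since 2,3-difluorophenoxy in place of (oxan-4-yl)amino gives a 31-fold lower number from compound 1 to compound 3 (1.49 log units; beyond the scatter), the opposite direction to a 4.6-fold higher number from compound 1 to compound 2 (0.67 log units; beyond the scatter). No evidence is available that accounts for this difference.

From the compounds shown here alone, it remains open whether the gain depends on the two fluorines or on removing the acetamido group. Unsubstituted phenyl, 3-fluorophenyl and 3-aminophenyl on the same oxygen would help separate these.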